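A few compounds are considered here, and "the series" means these few. Any claim that something is new, unique, unknown or untested is made for them only; others in the source may bear on it.

Compound 1, `Cc1ccc(-c2ccc3c(c2)C(=O)C(=O)N3)cc1`: 6000 nM
Compound 2, `COc1ccc(-c2ccc3c(c2)C(=O)C(=O)N3c2ccc(OC)cc2)cc1`: > 10000 nM
Compound 3, `COc1ccc(-c2ccc3c(c2)C(=O)C(=O)N3Cc2ccc(Cl)cc2)cc1`: 250 nM

In a functional assay on HepG2 cells (Homo sapiens) for antiproliferative activity, read by MTT assay, with a stated time of 48 h (a lower number here means a stronger inhibitor, a higher number a weaker inhibitor), compound 1 gives 6000 nM. Compound 2 reaches only (the limit of > 10000 nM in this assay, at which 1 of the 3 values shown sits), which is a limit of the assay and not a number. Among the compounds with values here, compound 3 gives 250 nM and stands lowest of the two numbers known, with compound 1 as its nearest neighbour. Within the data shown here, the only measured step is an at least 40-fold lower number from compound 2 to compound 3 (1.60 log units; beyond the scatter), in which a 4-chlorobenzyl took the place of a 4-methoxyphenyl on the amide-type nitrogen in a ring.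

Compound 4 is `COc1ccc(-c2ccc3c(c2)C(=O)C(=O)N3Cc2ccc(OC)c(OC)c2)cc1`, not yet measured. It differs from compound 3 in one place: 3,4-dimethoxyphenyl in place of 4-chlorophenyl on a saturated chain carbon bound to an amide-type nitrogen in a ring. Among the measured compounds shown here, the measured step exchanged the whole group on the amide-type nitrogen, so it does not test a change of substituents on a benzyl group that stays in place; no measured step bears directly on the move from compound 3 to compound 4. The expectation is therefore a small change, a 2.0-fold higher number from compound 3 to compound 4 (0.30 log units; within the scatter), leaning toward a somewhat higher number. Compound 4 is expected to give 500 nM, between 150 nM and 2000 nM.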

Compound 4, half-maximal inhibitory concentration: 1350 nM
For compound 4 the middle estimate is 2.7-fold (0.43 log units) below the measured one, within the range that was stated.
By their numbers in this assay, from the lowest: compound 3; then compound 4; then compound 1. At a limit, above all of these: compound 2.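

With the group on the amide-type nitrogen kept as a benzyl, changing only its aromatic ring still moves the result in this assay: a 5.4-fold higher number from compound 3 to compound 4 (0.73 log units; beyond the scatter). Activity at this position therefore depends on more than the presence of a ring on the saturated chain carbon, since the ring's substituents also count, and here 4-chlorophenyl gives the lower number of the pair. Nothing measured here explains why the 3,4-dimethoxyphenyl group gives the higher number.

This single exchange removes the chlorine and adds two methoxy groups at once, so the share of each remains unresolved. The compounds shown also leave open how a plain phenyl, a ring bearing an amine or a carboxylic acid, or a longer chain on the amide-type nitrogen would compare.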